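This account rests on a few compounds, and the source may have more. Where it says the series, first, only, none or still open, it means among the compounds named here.

Measured compounds and their numbers in a functional assay on cells for inhibition of growth hormone secretagogue receptor type 1 (Homo sapiens), read by FLIPR and calcium flux; on this read-out higher numbers stand for an effect only at larger amounts of compound and lower numbers for an effect already at smaller amounts:
compound 1 `CC(C)(N)C(=O)N[C@H](COCc1cccc(Cl)c1Cl)c1nnnn1CCOC(=O)NCCCCO` — compound 1 gives 0.61 nM
compound 2 `CC(C)(N)C(=O)N[C@H](COCc1cc(Cl)cc(Cl)c1)c1nnnn1CCOC(=O)NCCCCO` — compound 2 gives 6.75 nM

Compound 1 stands with the lowest of the two numbers; its nearest neighbour is compound 2, and the step of an 11-fold higher number from compound 1 to compound 2 (1.04 log units; beyond the scatter) lies beyond the scatter. That step is the only one measured so far, and it concerns the same place as the change now considered: the aryl group on a saturated chain carbon bound to an oxygen on a saturated carbon.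

Compound 3 `CC(C)(N)C(=O)N[C@H](COCc1ccccc1-c1cccnc1)c1nnnn1CCOC(=O)NCCCCO` is not yet measured in this assay. It differs from compound 1 as follows: 2-(pyridin-3-yl)phenyl in place of 2,3-dichlorophenyl on a saturated chain carbon bound to an oxygen on a saturated carbon. Among the compounds with values here, the one measured step shows that rearranging the two chlorines on this ring already moves the number well beyond the scatter, so the read-out is sensitive at this position. Within the data shown here, replacing the ring altogether by 2-(pyridin-3-yl)phenyl is a larger change than the one measured, and no step tells in which direction it goes. On the strength of compound 1 having the low number 0.61 nM and of the sensitivity seen in an 11-fold higher number from compound 1 to compound 2 (1.04 log units; beyond the scatter), a higher number is expected, of a size like an 8.2-fold higher number from compound 1 to compound 3 (0.91 log units; beyond the scatter). For compound 3 the estimate is 5 nM, within 0.8 nM to 40 nM.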

Compound 3, half-maximal effective concentration: 1.18 nM
Estimate against measurement, compound 3: 4.2-fold (0.63 log units) above, and the stated range covers the measured number.
By their numbers in this assay, from the lowest: compounds 1 and 3 (each within the scatter of the next); then compound 2.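

In this assay, the position on a saturated chain carbon bound to an oxygen on a saturated carbon admits a much larger change than the move of the two chlorines might have suggested: with 2-(pyridin-3-yl)phenyl, which has 12 heavy atoms and 1 hydrogen-bond acceptor, in place of 2,3-dichlorophenyl, which has 8 heavy atoms and none, the step stays within the scatter (a 1.9-fold higher number from compound 1 to compound 3 (0.29 log units; within the scatter)). The same group also separates clearly from 3,5-dichlorophenyl (a 5.7-fold lower number from compound 2 to compound 3 (0.76 log units; beyond the scatter)), so among these three compounds the 3,5-dichlorophenyl compound alone stands apart, and a second aromatic ring is compatible with a low number here. No measurement shown gives a reason for either step.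

The compounds leave open whether the ring nitrogen of the pyridin-3-yl group contributes anything, which a plain phenyl ring in its place would address. They also leave open whether the two-ring group keeps its number when the ring carries a further substituent such as a methoxy group or a fluorine, or when a pyridin-4-yl group replaces the pyridin-3-yl group.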